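The source may hold more compounds than are shown below. What is called first, only, known or untested is meant among the compounds shown, and "the series" means these compounds.

Measured so far:
compound 1, `CN(C)CCNc1ccnc2cc(OCc3ccc(F)cc3)ccc12`: 780 nM
compound 2, `CCCCCCCCOc1ccc2c(Cl)ccnc2c1`: 3240 nM

The series is followed in a functional assay on NCI-H1650 cells (Homo sapiens) for cytotoxicity, read by MTT assay, with a stated time of 48 h; a lower number here means a stronger inhibitor, a higher number a weaker inhibitor. Going by the values given here, of the two numbers so far, compound 1 stands lowest with 780 nM; the nearest is compound 2 at 3240 nM, a gap beyond the scatter. Among the compounds with values here, the two differ in more than one place, so no single step between them can be read, and the gap is left as it is.

The next compound, compound 3 `CN(C)CCNc1ccnc2cc(OCc3ccccc3)ccc12`, is not yet measured. It differs from compound 1 in one place: hydrogen in place of fluoro on an aromatic carbon. Cut one bond further out, the change reads 4-fluorobenzyl to benzyl. Within the data shown here, no measured pair shows this step, and nothing among the compounds so far tells how it reads in this assay. For a change confined to one heavy atom, a step of no more than the usual scatter is expected, in either direction.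

For compound 3 the estimate is 900 nM, with a range of 400 nM to 2000 nM. The estimate for compound 3 means a step, a 1.2-fold higher number from compound 1 to compound 3 (0.06 log units; within the scatter), expected to stay within the scatter.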

Compound 3, half-maximal inhibitory concentration: 1620 nM
Estimate against measurement, compound 3: 1.8-fold (0.26 log units) below; low and high end bracket the measured number.
By their numbers in this assay, from the lowest: compound 1; then compounds 3 and 2 (each within the scatter of the next).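

In this assay, the series now has its first single-place comparison: hydrogen in place of fluoro on this aromatic carbon gives a 2.1-fold higher number from compound 1 to compound 3 (0.32 log units; beyond the scatter), a modest step. The earlier compounds shown here gave no reading at this position, and it now shows that a change of one heavy atom, on the ring of the 4-fluorobenzyl group, is enough to move the number beyond the scatter, with the fluoro compound holding the lower number. The direction and size of this step are established only for 4-fluorobenzyl to benzyl on the core of compound 1, and nothing at hand bears on what lies behind it.

Still open, as far as these compounds go, is whether other groups on this same carbon, such as chloro, methoxy, trifluoromethyl or a nitrile, would stay with fluoro or with hydrogen in this assay, and whether fluoro elsewhere on the ring would read the same. Also open, from the compounds shown here alone, is whether the step carries over when the amine chain of compound 1 gives way to another amine, such as a morpholine or a piperazine.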